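Extending a furan ring on an amide cytotoxicity series

The source may report more compounds than this note shows. Statements on the series, on what has been measured and on what is new or still open speak of the compounds shown alone.

Compound 1 `CCCCCCCCCCCCCCCCCCNC(=O)[C@@H](NC(=O)c1ccccc1)[C@@H](C)O` carries a phenyl group on the carbonyl carbon of its amide. In a functional assay on HepG2 cells (Homo sapiens) for cytotoxicity, read by MTT assay, with a stated time of 48 h (a higher number here means a weaker inhibitor, a lower number a stronger inhibitor), compound 1 gives only a limit of the assay, > 400000 nM. Compound 2 `CCCCCCCCCCCCCCCCCCNC(=O)[C@@H](NC(=O)c1ccco1)[C@@H](C)O` differs by a furan-2-yl group in that place, and in this assay compound 2 gives 42300 nM. For the measured compounds named here, the step of an at least 9.4-fold lower number from compound 1 to compound 2 (0.97 log units; beyond the scatter) is the one measured change, and it rests on a limit (the limit of > 400000 nM in this assay, at which 1 of the 2 values shown sits). Compound 2 therefore holds the only firm number shown, with the other value being a limit.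

Compound 3 `CCCCCCCCCCCCCCCCCCNC(=O)[C@@H](NC(=O)c1cc2ccccc2o1)[C@@H](C)O` differs from compound 2 by 1-benzofuran-2-yl in place of furan-2-yl on a carbonyl carbon. Going by the values given here, only the step from compound 1 to compound 2 bears on this change, and it points toward smaller numbers when phenyl gives way to a furan, so adding a fused benzene ring to that furan is expected to move the number little. The estimate for compound 3 is a step of a 1.2-fold lower number from compound 2 to compound 3 (0.08 log units; within the scatter) that stays within the scatter. Compound 3 is estimated at 35000 nM, between 9000 nM and 140000 nM.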

Compound 3, half-maximal inhibitory concentration: > 200000 nM
Compound 3: only a limit was reported; the forecaster's own chance of this, stated with the estimate: 10%; at least 5.7-fold (0.75 log units) between middle value and limit.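

Fusing a benzene ring onto the furan-2-yl group gives an at least 4.7-fold higher number from compound 2 to compound 3 (0.67 log units; beyond the scatter) in this assay, so the lower number seen with the furan-2-yl group does not carry over to the larger 1-benzofuran-2-yl group on this carbonyl carbon. Compound 3 gives only a limit, so this step has a smallest size but no exact one: the limit of > 200000 nM in this assay, at which 1 of the 3 values shown sits.

Of the three groups tried on this carbonyl carbon, only furan-2-yl gives a firm number, and the step between compound 1 and compound 3 cannot be read, as both values are limits.

On these data alone, it remains open whether a small five-membered ring is what matters, which a thiophen-2-yl group in the same place could test. A methyl group on the furan ring could show whether any added atoms on that ring raise the number.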